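From a saturated amide chain to an unsaturated one

The source may hold more compounds than are shown below. What is called first, only, known or untested is meant among the compounds shown, and "the series" means these compounds.

Measured in a functional assay on MCF7 cells (Homo sapiens) for inhibition, read by sulforhodamine B assay, with a stated time of 72 h; a higher number here means a weaker inhibitor of growth, a lower number a stronger inhibitor of growth:
Compound 1 `O=C(CCc1ccncc1-c1ccc2ccccc2c1)N1CCOCC1`: > 10000 nM, a limit.
Compound 2 `CCOC(=O)/C=C/c1ccncc1-c1ccc2c(ccn2C)c1`: 8670 nM.
Compound 3 `CNC(=O)CCc1ccncc1-c1ccc2ccccc2c1`: > 10000 nM, a limit.

Compound 3 has no exact number, and like compound 1 it stands at the limit of > 10000 nM in this assay, at which 2 of the 3 values shown sit. Compound 4 `CN(C)C(=O)/C=C/c1ccncc1-c1ccc2ccccc2c1` carries 2-(dimethylcarbamoyl)ethenyl in place of 2-(methylcarbamoyl)ethyl on an aromatic carbon, opposite the ring nitrogen (2-(dimethylcarbamoyl)ethenyl in place of 2-(methylcarbamoyl)ethyl on an aromatic carbon).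

Going by the values given here, the one measured step among the amides is a step that the two limits leave unreadable from compound 1 to compound 3, so it offers no size to carry over. Compound 2 also has a double bond in its chain and gives 8670 nM. Its core and its ester differ from those of compound 4, so it is only a loose guide.

Among the compounds with values here, no large step is therefore expected in this assay, and compound 4 should remain a weak inhibitor of growth. The expected change is an at least 1.1-fold lower number from compound 3 to compound 4 (0.04 log units; that floor lies within the scatter). For compound 4 the estimated value is 9000 nM. The expected range for compound 4 runs from 3500 nM to 20000 nM.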

Compound 4, concentration for 50% growth inhibition: 8190 nM
The estimate for compound 4 lay 1.1-fold (0.04 log units) above the measured number; measured number inside the range.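

In this assay, going by these compounds alone, compound 4 gives 8190 nM, the first exact number for an amide chain on this aromatic carbon, opposite the ring nitrogen. Replacing 2-(methylcarbamoyl)ethyl with 2-(dimethylcarbamoyl)ethenyl amounts to an at least 1.2-fold lower number from compound 3 to compound 4 (0.08 log units; that floor lies within the scatter), but only this floor is known and the true size could be larger, since compound 3 has no exact number: the limit of > 10000 nM in this assay, at which 2 of the 4 values shown sit. Even so, the exact number for compound 4 stays close to that limit, so this change does not make the amide a strong inhibitor of growth.

As far as these compounds go, the change adds a double bond to the chain and alters the amide nitrogen at once, so it remains open which part matters; 2-(dimethylcarbamoyl)ethyl and 2-(methylcarbamoyl)ethenyl would separate the two. Also open, from the compounds shown here alone, is how a carboxylic acid or an amine in place of the amide would behave here.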